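Fluoro to chloro on the anilino ring: an expected step

A few compounds are considered here, and "the series" means these few. Any claim that something is new, unique, unknown or untested is made for them only; others in the source may bear on it.

Compound 1 `CCS(=O)(=O)Nc1cc(-c2ccc3ncnc(Nc4cccc(F)c4)c3c2)cnc1OC` gives 9940 nM in a functional assay on A549 cells (Homo sapiens) for cytotoxicity, read by sulforhodamine B assay, with a stated time of 72 h; on this read-out higher numbers stand for weaker inhibition and lower numbers for stronger inhibition.
Compound 2 `CCS(=O)(=O)Nc1cc(-c2ccc3ncnc(Nc4ccc(OC)cc4)c3c2)cnc1OC` gives 3580 nM in this assay.
Compound 3 `CCS(=O)(=O)Nc1cc(-c2ccc3ncnc(Nc4ccc(F)c(C(=O)OC)c4)c3c2)cnc1OC` gives 3420 nM in this assay.

All three share one core and differ only in the aryl group carried on the nitrogen. Compound 3 has the lowest number of the three, but its gap to compound 2 is within the scatter, so the two cannot be ranked; only compound 1 sits clearly apart, as the step of a 2.9-fold lower number from compound 1 to compound 3 (0.46 log units; beyond the scatter) shows.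

The next compound keeps everything of compound 3 except one atom: chloro in place of fluoro on an aromatic carbon. This gives compound 4 `CCS(=O)(=O)Nc1cc(-c2ccc3ncnc(Nc4ccc(Cl)c(C(=O)OC)c4)c3c2)cnc1OC`, still to be measured in this assay.

Going by the values given here, none of the measured steps exchanges one halogen for another. The steps of a 2.8-fold lower number from compound 1 to compound 2 (0.44 log units; beyond the scatter) and a 2.9-fold lower number from compound 1 to compound 3 (0.46 log units; beyond the scatter) replace the whole aryl group, and the step of a 1.0-fold lower number from compound 2 to compound 3 (0.02 log units; within the scatter), which swaps a methoxy for a fluoro together with an ester, stays within the scatter. Nothing here suggests that a single halogen swap would move the number beyond the scatter, so compound 4 is expected to land close to compound 3, with the estimated step of a 1.0-fold lower number from compound 3 to compound 4 (0.00 log units; within the scatter).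

Compound 4 is therefore estimated at 3400 nM, within the range 1500 nM to 7500 nM.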

Compound 4, half-maximal inhibitory concentration: 2130 nM
The estimate for compound 4 lay 1.6-fold (0.20 log units) above the measured number; low and high end bracket the measured number.
By their numbers in this assay, from the lowest: compounds 4, 3 and 2 (each within the scatter of the next); then compound 1.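

Going by these compounds alone, exchanging fluoro for chloro on the aromatic carbon ortho to the methoxycarbonyl group gives a 1.6-fold lower number from compound 3 to compound 4 (0.21 log units; within the scatter) in this assay and is the first halogen-for-halogen step, so on this read-out the two halogens cannot be told apart at this position. Compound 4 also cannot be ranked against the methoxy-bearing compound 2, as the step of a 1.7-fold lower number from compound 2 to compound 4 (0.23 log units; within the scatter) shows, whereas replacing the whole aryl group of compound 1 gives a 4.7-fold lower number from compound 1 to compound 4 (0.67 log units; beyond the scatter) and so places compound 4, like compound 3, clearly apart from compound 1. No measurement shown here offers an explanation for any of these steps.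

As far as these compounds go, it remains open whether this ring carbon would give a similar number with something other than a halogen, such as a methyl group or an amine, or with no substituent at all. The role of the methoxycarbonyl group is also unsettled, since the compounds shown do not compare it directly with a carboxylic acid or an amide at the same place on the 4-chlorophenyl ring.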